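Phenyl Replaces Difluorophenyl on the Ether Oxygen

The source may hold more compounds than are shown below. What is called first, only, known or untested is meant among the compounds shown, and "the series" means these compounds.

Measured compounds:
Compound 1 `Cn1cc(-c2cc(C(C)(C)O)ccc2Oc2ccc(F)cc2F)c2cc(C(=O)NCc3ccc(C(=O)Nc4ccccc4N)cc3)[nH]c2c1=O` gives 90 nM in a functional assay on MV4-11 cells (Homo sapiens) for antiproliferative activity, read by CCK-8 assay, with a stated time of 72 h; a higher number here means a weaker inhibitor, a lower number a stronger inhibitor.
Compound 2 `Cn1cc(-c2ccccc2Oc2ccccc2)c2cc(C(=O)NCCCCC(=O)Nc3ccccc3N)[nH]c2c1=O` gives 240 nM in this assay.
Compound 3 `CC(C)Oc1ccccc1-c1cn(C)c(=O)c2[nH]c(C(=O)NCc3ccc(C(=O)Nc4ccccc4N)cc3)cc12` gives 130 nM in this assay.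

Compound 1 has the lowest number of the three. Its gap to compound 3 lies within the usual scatter, so those two cannot be told apart on these data; its gap to compound 2 lies beyond the scatter. Compound 4 `Cn1cc(-c2cc(C(C)(C)O)ccc2Oc2ccccc2)c2cc(C(=O)NCc3ccc(C(=O)Nc4ccccc4N)cc3)[nH]c2c1=O` has not yet been measured. It differs from compound 1 in one place: phenyl in place of 2,4-difluorophenyl on an oxygen on an aromatic ring. Among the measured compounds shown here, no measured pair shows this exact change, so its size is unknown here, and compounds 2 and 3 carry other changes as well. The expectation is a small step, a 1.4-fold higher number from compound 1 to compound 4 (0.16 log units; within the scatter), at most slightly toward a weaker inhibitor and possibly none beyond the scatter. Compound 4 is estimated at 130 nM, with a likely range from 55 nM to 320 nM.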

Compound 4, half-maximal inhibitory concentration: 100 nM
Estimate against measurement, compound 4: 1.3-fold (0.11 log units) above; the range from low to high includes it.
By their numbers in this assay, from the lowest: compounds 1, 4, 3 and 2 (each within the scatter of the next, the first and the last beyond it).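

Swapping 2,4-difluorophenyl for phenyl on the oxygen gives the first direct reading of this change: in this assay it produces a 1.1-fold higher number from compound 1 to compound 4 (0.05 log units; within the scatter). The two fluorines can therefore be removed from this position with no detectable change in this assay. Nothing measured here offers an explanation for this result. As far as these compounds go, what remains open is how a carboxylic acid or a dimethylamino group on this phenyl ring would shift the number, and whether a single fluorine would behave like the pair.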